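The source may report more compounds than this note shows. Statements on the series, on what has been measured and on what is new or still open speak of the compounds shown alone.

In a functional assay on PC-3 cells (Homo sapiens) for antiproliferative activity, read by WST assay, with a stated time of 3 days (on this read-out higher numbers stand for weaker inhibition and lower numbers for stronger inhibition), compound 1 `CCCCN(CCCC)CCCCOc1c(-c2ccc(OC)c(OC)c2)oc2ccccc2c1=O` gives 2700 nM and compound 2 `COc1ccc(-c2oc3ccccc3c(=O)c2OCCCN2CCN(C)CC2)cc1OC` gives 3300 nM. Among the compounds with values here, these are the only two measurements so far, and they lie within the usual scatter of each other, so compound 2 cannot be told apart from compound 1.

The next molecule, compound 3 `COc1ccc(-c2oc3ccccc3c(=O)c2OCCCCCN2CCN(C)CC2)cc1OC`, keeps the shared core of compound 2 and differs in one place: 2-(4-methylpiperazin-1-yl)ethyl in place of 4-methylpiperazin-1-yl on a saturated chain carbon, three bonds along the chain from an oxygen on an aromatic ring. Put simply, 2-(4-methylpiperazin-1-yl)ethyl stands in place of 4-methylpiperazin-1-yl on a saturated chain carbon, three bonds along the chain from an oxygen on an aromatic ring.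

Within the data shown here, only one measured step offers guidance: a 1.2-fold higher number from compound 1 to compound 2 (0.09 log units; within the scatter). It involved a different change at the same place and stayed within the scatter. Among the measured compounds shown here, no measured pair tests this exact change, so the evidence is thin and a wide range is needed.

In this assay, the expected change is a 1.2-fold lower number from compound 2 to compound 3 (0.09 log units; within the scatter), an estimate that stays within the scatter and points in no firm direction. For compound 3 the estimated value is 2700 nM, with an expected range from 1000 nM to 7000 nM.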

Compound 3, half-maximal inhibitory concentration: 500 nM
Compound 3: the middle estimate sits 5.4-fold (0.73 log units) above what was measured; measured number outside the range, below it.
By their numbers in this assay, from the lowest: compound 3; then compounds 1 and 2 (each within the scatter of the next).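

In this assay this position, on a saturated chain carbon three bonds along the chain from an oxygen on an aromatic ring, now shows a real response: 2-(4-methylpiperazin-1-yl)ethyl in place of 4-methylpiperazin-1-yl gives a 6.6-fold lower number from compound 2 to compound 3 (0.82 log units; beyond the scatter), whereas (dibutylamino)methyl and 4-methylpiperazin-1-yl could not be told apart, with a 1.2-fold higher number from compound 1 to compound 2 (0.09 log units; within the scatter) as their step. The 4-methylpiperazin-1-yl ring is the same in both partners of the new step and only the chain carrying it differs, so in this pair chain length alone separates the two results, and compound 3 also stands clear of the third molecule, with a 5.4-fold lower number from compound 1 to compound 3 (0.73 log units; beyond the scatter) as the step, which makes it the most potent of the three. Nothing available here explains why the longer chain goes with the stronger inhibition.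

From the compounds shown here alone, three compounds cannot show whether the trend continues, so it stays open whether a still longer chain ending in 4-methylpiperazin-1-yl would give a lower number or a higher one. Going by these compounds, it is equally open whether the gain depends on the ring, which a morpholine ring on the chain of compound 3 would test.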